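Ester to ketone on the shared core: no guiding precedent

The source may hold more compounds than are shown below. What is called first, only, known or untested is meant among the compounds shown, and "the series" means these compounds.

Two compounds of the series have numbers in an assay on membranes from CHO cells for displacement of a labelled ligand from adenosine receptor A1 (Homo sapiens), read by scintillation counting, with a stated time of 60 min, tested at 1 uM (a lower number here means less inhibition, a higher number more inhibition at the concentration tested (going by the name of the read-out)), so far. Compound 1 `COC(=O)C1=C(C)NC(=O)NC1c1ccoc1` gives 8% in this assay. Compound 2 `CC1=C(C(=O)OC(C)(C)C)C(c2ccoc2)NC(=O)N1` gives 11% in this assay and stands at the top of the two numbers, though the step of a number 3 percentage points higher from compound 1 to compound 2 (within the scatter) is within the scatter, so the two compounds show the same behaviour as far as this assay can tell. Compound 3 `CC(=O)C1=C(C)NC(=O)NC1c1ccoc1` has not yet been measured in this assay. It differs from compound 2 by methyl in place of tert-butoxy on a carbonyl carbon. Within the data shown here, the only measured step, a number 3 percentage points higher from compound 1 to compound 2 (within the scatter), concerns the alkyl on the ester oxygen rather than the carbonyl carbon, and it produced no movement beyond the scatter. Among the measured compounds shown here, no measured pair covers the replacement of the whole tert-butoxy by methyl on the carbonyl carbon, so there is no precedent for this change in this assay. With that gap in mind, the expected step of a number 1 percentage points lower from compound 2 to compound 3 (within the scatter) is none beyond the scatter. For compound 3 the estimate in this assay is therefore 10%, with a range from 0% to 25%.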

Compound 3, a percentage reported as inhibition, at one concentration (the size of the read-out at that concentration, not a potency): 6%
Beside the measured number, compound 3's estimate is 4 percentage points above it; low and high end bracket the measured number.
By their numbers in this assay, from the lowest: compounds 3, 1 and 2 (each within the scatter of the next).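

In this assay, methyl in place of tert-butoxy on a carbonyl carbon gives a number 5 percentage points lower from compound 2 to compound 3 (within the scatter), and methyl in place of methoxy at the same carbon gives a number 2 percentage points lower from compound 1 to compound 3 (within the scatter). The earlier pair varied only the alkyl on the ester oxygen, whereas these steps replace the whole alkoxy group, and the ketone compound 3 at 6% cannot be told apart from either ester in this read-out, which reports inhibition at one concentration and is not a potency. The three compounds therefore show level numbers in this assay with ester or ketone at this position, but no supporting measurement bears on this result.

Still open, going by these compounds, is whether a carboxylic acid, an amide or a longer chain on this carbonyl carbon would move the number beyond the scatter in this assay. Also open, on these data alone, is whether any group on this carbonyl carbon matters once a change elsewhere on the shared core gives a larger reading, as all three compounds share that core and differ only here.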